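Chloro on the pyridine ring across two cores

A few compounds are considered here, and "the series" means these few. Any claim that something is new, unique, unknown or untested is made for them only; others in the source may bear on it.

Measured compounds:
compound 1, `Nc1ccccc1NC(=O)c1ccc(NC(=S)NCc2ccc(Cl)nc2)cc1`, 6100 nM
compound 2, `Nc1ccccc1NC(=O)c1ccc(NC(=S)NCc2cccnc2)cc1`, 1000 nM
compound 3, `Nc1ccccc1NC(=O)c1ccc(NC(=O)NCc2cccnc2)cc1`, 9400 nM

All three were run in a functional assay on HCT-116 cells (Homo sapiens) for cytotoxicity, read by MTT assay, with a stated time of 72 h; a lower number here means a stronger inhibitor, a higher number a weaker inhibitor. Compound 2 and compound 1 share a core and differ in one place, (chloro in place of hydrogen on an aromatic carbon); that single change gives a 6.1-fold higher number from compound 2 to compound 1 (0.79 log units; beyond the scatter). Compound 3 carries a second core; the difference between the two cores is not broken down here. In this assay compound 3 gives the highest number of the three, while compound 2 gives the lowest, and the gap from compound 3 to compound 1 lies within the scatter.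

Compound 4, `Nc1ccccc1NC(=O)c1ccc(NC(=O)NCc2ccc(Cl)nc2)cc1`, is not yet measured. It is made from compound 3 by chloro in place of hydrogen on an aromatic carbon, the same change as from compound 2 to compound 1, at the same place. Among the compounds with values here, only that one earlier step is available as a guide. For compound 4 the expected step is a 4.3-fold higher number from compound 3 to compound 4 (0.63 log units; beyond the scatter), resting on the earlier step of a 6.1-fold higher number from compound 2 to compound 1 (0.79 log units; beyond the scatter) applied on top of the value of compound 3, 9400 nM. Compound 4 is therefore estimated at 40000 nM, with a range from 12000 nM to 150000 nM, and a fair chance that this assay returns only a limit.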

Compound 4, half-maximal inhibitory concentration: 5200 nM
Beside the measured number, compound 4's estimate is 7.7-fold (0.89 log units) above it; the measured number lies below the stated range.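

In this assay, the change from pyridin-3-yl to 6-chloropyridin-3-yl does not carry over from one core to the other: the same change on two cores in this assay, a 6.1-fold higher number (0.79 log units; beyond the scatter) from compound 2 to compound 1 and a 1.8-fold lower number (0.26 log units; within the scatter) from compound 3 to compound 4, 11-fold (1.04 log units) apart, beyond the scatter of two such steps

On the core of compound 3, the change gives a 1.8-fold lower number from compound 3 to compound 4 (0.26 log units; within the scatter), so this pair gives no sign of the penalty seen as a 6.1-fold higher number from compound 2 to compound 1 (0.79 log units; beyond the scatter) on the other core. With a single pair on each core, these results show that the earlier step cannot be used as a transferable increment here, but they do not show why the two cores differ or whether the same mismatch would hold for other changes in the series.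

The compounds shown leave open whether a fluoro, bromo, methyl or methoxy group at the same place would also give core-dependent steps, or whether this behaviour is confined to chloro. They also leave open how either core would respond if a longer chain replaced the (pyridin-3-yl)methyl link.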